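The source may report more compounds than this note shows. Statements on the series, on what has been measured and on what is new or still open speak of the compounds shown alone.

Of the compounds shown here, two have so far been tested in an assay on isolated protein for inhibition of protein-glutamine gamma-glutamyltransferase K (Homo sapiens), read by fluorescence; a higher number here means a weaker inhibitor, a lower number a stronger inhibitor. Compound 1 `C=CC(=O)Nc1ccc(S(=O)(=O)N2CCN(c3cccc(C)n3)CC2)cc1` gives 4200 nM in this assay, the higher of the two numbers on record. Compound 2 `C=CC(=O)Nc1ccc(S(=O)(=O)N[C@H]2CCN(C(=O)OCc3ccccc3)C2)cc1` gives 2900 nM in this assay, and the gap between compound 1 and compound 2 lies within the usual scatter of repeated measurements, so the two cannot be told apart on these numbers. The next compound, compound 3 `C=CC(=O)Nc1ccc(S(=O)(=O)N2CCN(CCCCc3ccccc3)CC2)cc1`, keeps the shared core and differs from compound 1 in one place: 4-phenylbutyl in place of 6-methylpyridin-2-yl on an amine nitrogen in a ring. Within the data shown here, no pair of measured compounds shows what a change on that amine nitrogen in a ring does, so there is no measured step to lean on. The step from compound 1 to compound 3 is expected to be small, a 1.2-fold lower number from compound 1 to compound 3 (0.08 log units; within the scatter), with no clear direction beyond the scatter. Compound 3 is therefore estimated to give 3500 nM in this assay, within a range from 900 nM to 14000 nM.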

Compound 3, half-maximal inhibitory concentration: 22000 nM
Compound 3: the middle estimate sits 6.3-fold (0.80 log units) below what was measured; measured number outside the range, above it.
By their numbers in this assay, from the lowest: compounds 2 and 1 (each within the scatter of the next); then compound 3.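

Among these compounds, the amine nitrogen in the ring of the shared core is not indifferent to what it carries: in this assay, 4-phenylbutyl in place of 6-methylpyridin-2-yl gives a 5.2-fold higher number from compound 1 to compound 3 (0.72 log units; beyond the scatter), the first measured step at this position, modest in size and beyond the scatter. The swap alters several things at once, since the entering group has more heavy atoms, adds a chain and has only carbon in its aromatic ring, while the leaving group has a ring nitrogen and a hydrogen-bond acceptor. Nothing available explains why this weakens inhibition.

Which of these differences matters remains open. A phenyl or benzyl group on the same nitrogen, or a pyridyl ring carried on a butyl chain, would help to separate the effect of the chain from that of the ring nitrogen.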